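Swapping a methyl for a chloro on one aryl ring

The source may hold more compounds than are shown below. What is called first, only, known or untested is meant among the compounds shown, and "the series" means these compounds.

Compound 1 `Cc1ccc(C2CC(c3ccc(Cl)cc3)=NN2c2nc3ccc(S(N)(=O)=O)cc3s2)cc1` was tested in a functional assay on the whole organism (strain Wistar) for inhibition, with Rattus norvegicus as the target, read by paw edema, with stated times of 1 h and 5 h, at a dose of 20 mg/kg by the oral route (on this read-out higher numbers stand for more inhibition at the one dose given (going by the name of the read-out) and lower numbers for less inhibition), where compound 1 gives 14%. Two related compounds sit at the same level: compound 2 `CN(C)c1ccc(C2CC(c3ccc(Br)cc3)=NN2c2nc3ccc(S(N)(=O)=O)cc3s2)cc1` gives 14% in this assay, and compound 3 `Cc1ccc(C2CC(c3ccc(Br)cc3)=NN2c2nc3ccc(S(N)(=O)=O)cc3s2)cc1` gives 14%. On these numbers compound 1 stands level with both of them, and neither can be set above the other.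

The next compound, compound 4 `NS(=O)(=O)c1ccc2nc(N3N=C(c4ccc(Cl)cc4)CC3c3ccc(Cl)cc3)sc2c1`, differs from compound 1 in one place: chloro in place of methyl on an aromatic carbon.

Among the measured compounds shown here, no measured step carries this exact change. The two steps that exist both touch a single aryl substituent and both stayed flat: no change at the digits printed from compound 1 to compound 3 (within the scatter), and no change at the digits printed from compound 2 to compound 3 (within the scatter). One of them alters the same ring as the change to compound 4, the other the opposite ring, and neither moved the read-out beyond the scatter. On that basis the step to compound 4 is expected to be small, with no direction beyond the scatter, so no change at the digits printed from compound 1 to compound 4 (within the scatter) is the expected step.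

Compound 4 is therefore estimated at 14% in this assay, within a range from 5% to 28%.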

Compound 4, a percentage reported as inhibition, in the whole organism at one dose (the size of the read-out at that dose, not a potency): 14%
Beside the measured number, compound 4's estimate shows no gap at the digits printed; the range from low to high includes it.
By their numbers in this assay, from the lowest: compounds 1, 2, 3 and 4 (each within the scatter of the next).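

In this assay, among the compounds shown here, the exchange of methyl for chloro on the aromatic carbon para to a large group, 4-methylphenyl to 4-chlorophenyl, gives no change at the digits printed from compound 1 to compound 4 (within the scatter), so this position now has a direct reading for this change, where the earlier steps covered only bromo for chloro and methyl for dimethylamino. With this step, three single-group exchanges on the aryl rings have been read, and none of them separates the compounds at this one dose; compound 4 also carries 4-chlorophenyl on both sides of the shared core and still stays level with the others. No measurement shown here bears on why the read-out stays flat across these exchanges.

As far as these compounds go, all four compounds hold a small single-atom or small substituent at these aryl positions, so it remains open whether a carboxylic acid, a primary amine or a longer alkyl chain in the same place would move the read-out beyond the scatter. From the compounds shown here alone, it also remains open whether the flat picture holds at other doses, since a single dose gives the size of the effect there and says nothing of potency.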